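The source may report more compounds than this note shows. Statements on the series, on what has been measured and on what is new or still open speak of the compounds shown alone.

Among the compounds with values here, in an assay on C3H 10T1/2 cells for inhibition of Sonic hedgehog protein (Mus musculus), read by a luciferase reporter (a lower number here means a stronger inhibitor, a higher number a weaker inhibitor), compound 2 `Cc1nc(C(F)(F)F)ccc1C(=O)Nc1ccc(Cl)c(C(=O)Nc2ccccc2)c1` gives 140 nM, the highest of the two numbers so far; its nearest neighbour, compound 1 `Cc1nc(C(F)(F)F)ccc1C(=O)Nc1ccc(Cl)c(-c2nc3ccccc3[nH]2)c1`, gives 12 nM. Within the data shown here, the single measured step, a 12-fold higher number from compound 1 to compound 2 (1.07 log units; beyond the scatter), traded a ring joined to an aromatic carbon for a phenylcarbamoyl group. Compound 3 `Cc1nc(C(F)(F)F)ccc1C(=O)Nc1ccc(Cl)c(-c2ncccn2)c1` moves the other way: pyrimidin-2-yl in place of phenylcarbamoyl on an aromatic carbon. Because compound 1 with its directly joined ring gives 12 nM, a fall beyond the scatter is expected here, a 4.7-fold lower number from compound 2 to compound 3 (0.67 log units; beyond the scatter). Compound 3 is therefore estimated at 30 nM, with a likely range from 10 nM to 90 nM.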

Compound 3, half-maximal inhibitory concentration: 8000 nM
Beside the measured number, compound 3's estimate is 270-fold (2.43 log units) below it; measured number outside the range, above it.
By their numbers in this assay, from the lowest: compound 1; then compound 2; then compound 3.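

In this assay, joining a ring directly at this position does not by itself give a strong inhibitor: pyrimidin-2-yl in place of phenylcarbamoyl gives a 57-fold higher number from compound 2 to compound 3 (1.76 log units; beyond the scatter), and in place of 1H-benzimidazol-2-yl it gives a 670-fold higher number from compound 1 to compound 3 (2.82 log units; beyond the scatter). Of these two directly joined rings, only the 1H-benzimidazol-2-yl ring of compound 1 gives a lower number than the phenylcarbamoyl group of compound 2, so the choice of ring matters greatly here. No measurement at hand explains this difference. Still open, as far as these compounds go, is whether a smaller 1H-imidazol-2-yl ring would give a number nearer that of compound 1 or compound 3.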